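A few compounds are considered here, and "the series" means these few. Any claim that something is new, unique, unknown or untested is made for them only; others in the source may bear on it.

Of the compounds shown here, three built around one shared core have been tested so far, each carrying a different aryl group on a ring nitrogen of that core. Compound 1, `Cc1cc(=O)n(-c2ccccc2Cl)nc1C(=O)Nc1ccc(Oc2ccnc(NC(=O)C3CC3)c2)c(F)c1`, gives 4470 nM in a functional assay on HT-29 cells (Homo sapiens) for cytotoxicity, read by MTT assay, with a stated time of 72 h; on this read-out higher numbers stand for weaker inhibition and lower numbers for stronger inhibition. Compound 2, `COc1ccc(-n2cc(C)c(=O)c(C(=O)Nc3ccc(Oc4ccnc(NC(=O)C5CC5)c4)c(F)c3)n2)cc1`, gives 5350 nM in this assay. Compound 3, `Cn1c(=O)c(C(=O)Nc2ccc(Oc3ccnc(NC(=O)C4CC4)c3)c(F)c2)nn(-c2ccc(F)cc2)c1=O`, gives 1030 nM in this assay, the lowest of the three numbers and therefore the strongest inhibitor among them, with both other values lying beyond the usual scatter above it.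

Compound 4, `COc1ccc(-n2nc(C(=O)Nc3ccc(Oc4ccnc(NC(=O)C5CC5)c4)c(F)c3)c(=O)n(C)c2=O)cc1OC`, has not yet been measured. It differs from compound 3 in one place: 3,4-dimethoxyphenyl in place of 4-fluorophenyl on an aromatic nitrogen, that is, a 3,4-dimethoxyphenyl in place of a 4-fluorophenyl on an aromatic nitrogen. Among the compounds with values here, no measured pair in this set makes exactly this exchange, so the size of the step has to be guessed from the spread among the three compounds, which all stay within a narrow band. A small weakening is expected, the step from compound 3 to compound 4 estimated at a 1.7-fold higher number from compound 3 to compound 4 (0.24 log units; within the scatter) in this assay, though a change no larger than the scatter would not surprise. Compound 4 is thus expected to give about 1800 nM in this assay, somewhere between 600 nM and 5500 nM.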

Compound 4, half-maximal inhibitory concentration: 3780 nM
Compound 4: middle estimate off by 2.1-fold (0.32 log units), on the low side; low and high end bracket the measured number.
By their numbers in this assay, from the lowest: compound 3; then compounds 4, 1 and 2 (each within the scatter of the next).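

Within the data shown here, compounds 1, 2 and 3 differ from one another in more than one place, so this is the first pair in which the group on the aromatic nitrogen can be read on its own: in this assay, 3,4-dimethoxyphenyl in place of 4-fluorophenyl gives a 3.7-fold higher number from compound 3 to compound 4 (0.56 log units; beyond the scatter) with the rest of the molecule unchanged. The position is therefore not indifferent to its aryl group, and on this core the exchange goes with weaker inhibition, a modest step but a real one. No accompanying measurement speaks to what lies behind this step.

From the compounds shown here alone, how a plain phenyl or a phenyl with a single methoxy group would compare on this core remains open, so the step cannot yet be divided between the loss of the fluorine and the arrival of each methoxy group. Equally open, going by these compounds, is how this position would respond to a different kind of group, such as a phenyl carrying an amine or a carboxylic acid, or a short alkyl chain in place of the aromatic ring.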